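Series notes: amide arm moved onto the aromatic ring

The compounds below may be only part of what the source reports. "The series", "measured", "known", "first", "only" and "open" are said of these compounds alone.

Measured in an assay (Ovis aries) for binding affinity to melatonin receptor type 1A (Homo sapiens); a higher number here means a weaker inhibitor, a lower number a stronger inhibitor:
compound 1, `COc1ccc2cccc(CCCC(N)=O)c2c1`, gives 20 nM
compound 2, `CNC(=O)CCc1cccc2ccc(OC)cc12`, gives 12.6 nM
compound 3, `COc1ccc2cccc(CONC(C)=O)c2c1`, gives 7.94 nM

Compound 3 has the lowest of the three numbers. Its nearest neighbour is compound 2, and the step of a 1.6-fold lower number from compound 2 to compound 3 (0.20 log units; within the scatter) is within the scatter, so the two cannot be ordered. Against compound 1 the step of a 2.5-fold lower number from compound 1 to compound 3 (0.40 log units; beyond the scatter) is beyond the scatter but modest. The remaining step, a 1.6-fold lower number from compound 1 to compound 2 (0.20 log units; within the scatter), is also within the scatter. All three measured steps exchange one side group for another on a saturated chain carbon; none of them touches the chain itself.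

Compound 4, `CNC(=O)c1cccc2ccc(OC)cc12`, differs from compound 3 as follows: a group of 4 heavy atoms (2 carbon, 1 nitrogen, 1 oxygen; no ring) in place of a group of 6 heavy atoms (3 carbon, 1 nitrogen, 2 oxygen; no ring), on an aromatic carbon. The whole saturated arm disappears and the amide sits directly on the aromatic carbon. Among the compounds with values here, no measured step bears directly on this change. The side-group swaps gave small steps, but shortening the arm is a different kind of change, and the three compounds with intact arms give no guide to its size. A weaker inhibitor is expected, with wide uncertainty.

For compound 4 the estimated step is a 25-fold higher number from compound 3 to compound 4 (1.40 log units; beyond the scatter). Compound 4 is expected to give 200 nM, with a range from 30 nM to 2000 nM.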

Compound 4, half-maximal inhibitory concentration: 1260 nM
Compound 4: the middle estimate sits 6.3-fold (0.80 log units) below what was measured; low and high end bracket the measured number.
By their numbers in this assay, from the lowest: compounds 3, 2 and 1 (each within the scatter of the next, the first and the last beyond it); then compound 4.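

In this assay, the change at this aromatic carbon is of a different order from the side-group swaps on the intact arms: a 160-fold higher number from compound 3 to compound 4 (2.20 log units; beyond the scatter) and a 100-fold higher number from compound 2 to compound 4 (2.00 log units; beyond the scatter) and a 63-fold higher number from compound 1 to compound 4 (1.80 log units; beyond the scatter) are all large. The cleanest reading comes from the step from compound 2, where methylcarbamoyl replaces 2-(methylcarbamoyl)ethyl, so the amide end stays and only the saturated part of the arm goes. Compound 1, compound 2 and compound 3 differ in their arms yet stay within a modest spread, whereas compound 4, with no saturated arm, stands far apart, so the presence of such an arm counts for much more here than the exact make-up of the arms shown.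

No measurement at hand accounts for this loss.

Still open, from the compounds shown here alone, is whether a single saturated carbon between the aromatic carbon and the amide, as in a methylcarbamoylmethyl group, recovers part of the loss or whether the number changes only once a longer chain is present. Also open, going by these compounds, is how an amine or a carboxylic acid on this aromatic carbon would compare with methylcarbamoyl.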